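Acyl thiourea series: para-phenyl step on the benzyl arm

The source may hold more compounds than are shown below. What is called first, only, known or untested is meant among the compounds shown, and "the series" means these compounds.

In an assay on isolated protein for inhibition of histone deacetylase 11 (Homo sapiens), read by fluorescence, tested at 100 uM (a lower number here means less inhibition, a higher number more inhibition at the concentration tested (going by the name of the read-out)), compound 2 `O=C(NC(=S)NCc1ccccc1)c1ccccc1` gives "not active" (no number reported) and no number is reported for it. Compound 1 `O=C(NC(=S)NCc1ccc(C(F)(F)F)cc1)c1ccccc1` is in the same position, giving "not active" (no number reported) in this assay. Among the compounds with values here, compound 3 `O=C(NC(=S)NCc1ccccc1)c1ccccc1F` is the one entry with a number, giving 14% in this assay, a low read-out at the single concentration. Compound 4 `O=C(NC(=S)NCc1ccc(-c2ccccc2)cc1)c1ccccc1` carries phenyl in place of hydrogen on an aromatic carbon relative to compound 2. Within the data shown here, no step between measured compounds bears on this change, so nothing beyond the scatter is expected in this assay, with a further report of no activity a real possibility. Compound 4 is expected to give 10% in this assay, within 0% to 25%.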

Compound 4, a percentage reported as inhibition, at one concentration (the size of the read-out at that concentration, not a potency): 10%
Estimate against measurement, compound 4: no gap at the digits printed, within the range that was stated.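

Within the data shown here, compound 2 has no number, so no step to compound 4 can be read. No measured evidence bears on this result.
From the compounds shown here alone, whether the phenyl on the benzyl arm changes inhibition at all remains open.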